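This account rests on a few compounds, and the source may have more. Where it says the series, first, only, none or still open, it means among the compounds named here.

Compound 3, `CCOC(=O)CCCCCOc1cccc(CN(C(=O)c2ccc(-c3ccc(C(C)=O)s3)cc2)C(C)C)c1`, shares its core with compound 1, `CCOC(=O)CCCCCOc1cccc(CN(C(=O)c2ccc(-c3ccc4ccccc4c3)cc2)C(C)C)c1`, and compound 2, `CCOC(=O)CCCCCOc1cccc(CN(C(=O)c2ccc(-c3cccnc3)cc2)C(C)C)c1`, the three differing only in the group that sits on the aromatic carbon. In an ADME assay on HEK293 cells (Homo sapiens) for cytotoxicity, read by CellTiter-Glo and resazurin assay, with a stated time of 72 h (a lower number here means that less compound is needed, a higher number that more compound is needed for the effect), compound 3 gives only a limit of the assay, > 26000 nM. Compound 1 likewise gives a limit in this assay, > 26000 nM. Compound 2 gives the same kind of limit in this assay, > 26000 nM. So compound 3 stands where every measured value stands, at the limit of > 26000 nM in this assay, at which 3 of the 3 values shown sit, and no measured compound gives a number that would separate it from the others.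

Compound 4, `CCOC(=O)CCCCCOc1cccc(CN(C(=O)c2ccc(-c3ccc4c(c3)OCCO4)cc2)C(C)C)c1`, is reached by 2,3-dihydro-1,4-benzodioxin-6-yl in place of 5-acetylthiophen-2-yl on an aromatic carbon. Going by the values given here, three measured steps bear on it, all of them changes of the same aromatic group on the same core: a step that the two limits leave unreadable from compound 1 to compound 2, a step that the two limits leave unreadable from compound 1 to compound 3 and a step that the two limits leave unreadable from compound 2 to compound 3. None of them has a readable size, because each end sits at the limit of > 26000 nM in this assay, at which 3 of the 3 values shown sit. Across a naphthyl, a pyridyl and an acetylthiophenyl group the readout did not move off the limit, so for the benzodioxinyl group the expected step in this assay is a number no higher from compound 3 to compound 4 (the limit leaves the size open), with no readable direction. Compound 4 is therefore expected at 26000 nM, within 13000 nM to 80000 nM, most probably again reported only as a limit.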

Compound 4, half-maximal effective concentration: > 24400 nM
Compound 4: only a limit was reported; the forecaster's own chance of this, stated with the estimate: 85%; the middle value does not contradict the limit.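

In this assay, compound 4 is reported only as a limit, > 24400 nM. Its steps from compound 1, compound 2 and compound 3 cannot be read, each joining two limits. The compounds shown leave open whether any group at this place on the shared core gives a measurable value in this assay, and how these four groups would rank.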